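A few compounds are considered here, and "the series" means these few. Any claim that something is new, unique, unknown or untested is made for them only; others in the source may bear on it.

Of the compounds shown here, two built on one shared core have been measured in an in vitro functional assay on B300-19 cells for antagonist activity at C-C chemokine receptor type 4 (Homo sapiens), read by GTPgammaS binding; on this read-out higher numbers stand for weaker inhibition and lower numbers for stronger inhibition. Compound 1 `COc1ccc2c(NC3CCCCCC3)nc(N3CCC(N4CCCC4)CC3)nc2c1` gives 13 nM. Compound 2 `c1ccc2c(NC3CCCCCC3)nc(N3CCC(N4CCCC4)CC3)nc2c1` gives 200 nM. Of these two numbers compound 2 stands highest; its nearest neighbour is compound 1, and the step of a 15-fold higher number from compound 1 to compound 2 (1.19 log units; beyond the scatter) lies beyond the scatter.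

Compound 3 `COc1ccc2nc(N3CCC(N4CCCC4)CC3)nc(NC3CCCCCC3)c2c1` has not yet been measured. It differs from compound 2 in a single place: methoxy in place of hydrogen on an aromatic carbon, the carbon belonging to a six-membered aromatic ring of carbon only, part of a fused or bridged system of two rings, meta to a fused ring and para to a fused ring. Within the data shown here, the only measured step that bears on this change is the loss of the methoxy on going a 15-fold higher number from compound 1 to compound 2 (1.19 log units; beyond the scatter), which was large. Compound 3 restores a methoxy, but on a different aromatic carbon of that ring, so the step in this assay is expected to run back toward lower numbers, though perhaps not all the way. Compound 3 is therefore estimated to give 40 nM, with a range from 10 nM to 200 nM. That would mean an expected step of a 5.0-fold lower number from compound 2 to compound 3 (0.70 log units; beyond the scatter).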

Compound 3, half-maximal inhibitory concentration: 31 nM
Beside the measured number, compound 3's estimate is 1.3-fold (0.11 log units) above it; measured number inside the range.
By their numbers in this assay, from the lowest: compound 1; then compound 3; then compound 2.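

Methoxy in place of hydrogen on this aromatic carbon, meta to a fused ring and para to a fused ring, gives in this assay a step of a 6.5-fold lower number from compound 2 to compound 3 (0.81 log units; beyond the scatter), so the hydrogen of compound 2 can be improved on at this position as well. Until now, the only methoxy effect on record was a 15-fold higher number from compound 1 to compound 2 (1.19 log units; beyond the scatter), at a different aromatic carbon of the same ring, and it could not be told whether the benefit was confined to that one carbon. The two methoxy positions are not equivalent in their printed values, with compound 1 at 13 nM and compound 3 at 31 nM, but both sit well under the value of compound 2. No available data explain why methoxy lowers the number at either carbon.

The compounds shown leave open whether this position calls for methoxy as such, since a hydroxyl, a methyl or an ethoxy on the same carbon could land near compound 3 or near compound 2. They also leave open what two methoxy groups on the ring, one on each of these carbons, would give in this assay.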